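A few compounds are considered here, and "the series" means these few. Any claim that something is new, unique, unknown or untested is made for them only; others in the source may bear on it.

Measured so far in an assay on isolated protein for binding affinity to Equilibrative nucleoside transporter 1 (Homo sapiens); a higher number here means a weaker inhibitor, a lower number a stronger inhibitor:
compound 1 `CC(C)Sc1nc(N)nc2c1ncn2[C@@H]1O[C@H](CO)[C@@H](O)[C@H]1O` gives 191000 nM
compound 2 `Nc1nc(SCc2ccccc2[N+](=O)[O-])c2ncn([C@@H]3O[C@H](CO)[C@@H](O)[C@H]3O)c2n1` gives 4570 nM

Going by the values given here, compound 2 holds the lower of the two numbers; the only measured step in this assay, a 42-fold lower number from compound 1 to compound 2 (1.62 log units; beyond the scatter), separates it from compound 1. Compound 3 `CC(=O)c1ccccc1Sc1nc(N)nc2c1ncn2[C@@H]1O[C@H](CO)[C@@H](O)[C@H]1O` has not been measured. It differs from compound 2 by 2-acetylphenyl in place of 2-nitrobenzyl on a sulfur.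

Among the compounds with values here, the single step that bears on this change is a 42-fold lower number from compound 1 to compound 2 (1.62 log units; beyond the scatter). It shows that the group on the sulfur can shift the number a long way, the 2-nitrobenzyl giving the far lower number. Compound 3 carries a 2-acetylphenyl on the sulfur instead; two compounds do not tell whether such a group behaves more like the isopropyl or more like the 2-nitrobenzyl. Compound 3 is expected to show a step of a 4.4-fold higher number from compound 2 to compound 3 (0.64 log units; beyond the scatter), toward a higher number. Compound 3 is therefore estimated at 20000 nM, within 4000 nM to 100000 nM.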

Compound 3, half-maximal inhibitory concentration: 447000 nM
Estimate against measurement, compound 3: 22-fold (1.35 log units) below, outside the stated range (above it).
By their numbers in this assay, from the lowest: compound 2; then compound 1; then compound 3.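

In this assay a six-membered aromatic ring on the sulfur does not by itself give the low number: there is a 98-fold higher number from compound 2 to compound 3 (1.99 log units; beyond the scatter) and also a 2.3-fold higher number from compound 1 to compound 3 (0.37 log units; beyond the scatter) so the 2-acetylphenyl falls nearer the isopropyl than the 2-nitrobenzyl, and on the high side of both. This change replaces benzyl with phenyl and nitro with acetyl in one step, so the two compounds do not separate the contribution of either difference. Nothing measured here accounts for the size of these steps.

Still open, on these data alone, is how a 2-nitrophenyl or a 2-acetylbenzyl on the sulfur would read, since either would divide this step into its two parts. The compounds shown also leave untested an unsubstituted benzyl, and an amine or a carboxylic acid on the ring.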